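This account rests on a few compounds, and the source may have more. Where it says the series, first, only, none or still open, it means among the compounds named here.

Among the compounds with values here, in a functional assay on A549 cells (Homo sapiens) for cytotoxicity, read by WST assay, with a stated time of 48 h (a lower number here means a stronger inhibitor, a higher number a weaker inhibitor), compound 2 (`N#C/C(=C\c1c[nH]c2cc(F)ccc12)C(=O)c1c[nH]c2cc(F)ccc12`) gives 36100 nM, the higher of the two numbers so far, while compound 1 (`COc1ccc2c(/C=C(\C#N)C(=O)c3c[nH]c4cc(F)ccc34)c[nH]c2c1`) gives 5500 nM. Compound 3 (`N#C/C(=C\c1c[nH]c2cc(F)ccc12)C(=O)c1c[nH]c2ccccc12`) differs from compound 2 by hydrogen in place of fluoro on an aromatic carbon. Within the data shown here, the only measured step, a 6.6-fold higher number from compound 1 to compound 2 (0.82 log units; beyond the scatter), put fluoro in place of methoxy elsewhere in the molecule, so it is only a loose guide, and no measured step yet shows this fluoro leaving. A small drop, hardly beyond the scatter, is expected, with an estimated step of a 1.8-fold lower number from compound 2 to compound 3 (0.26 log units; within the scatter). Compound 3 is estimated at 20000 nM, with an expected range of 7000 nM to 55000 nM.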

Compound 3, half-maximal inhibitory concentration: 22700 nM
Beside the measured number, compound 3's estimate is 1.1-fold (0.05 log units) below it; measured number inside the range.
By their numbers in this assay, from the lowest: compound 1; then compounds 3 and 2 (each within the scatter of the next).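

In this assay, hydrogen in place of fluoro on this aromatic carbon gives a 1.6-fold lower number from compound 2 to compound 3 (0.20 log units; within the scatter). In this pair, the fluoro can therefore leave without a difference beyond the scatter, whereas the earlier step, fluoro in place of methoxy elsewhere in the molecule, did go beyond it. Nothing measured here explains either result.

The compounds shown compare only fluoro and hydrogen at this position. On these data alone, how a chloro group, an amine or a carboxylic acid there would compare remains open.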